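Replacing a lactam ring by an amino group on a chromone ether

The source may hold more compounds than are shown below. What is called first, only, known or untested is meant among the compounds shown, and "the series" means these compounds.

Measured compounds:
- compound 1, `COc1cc(OC)c2c(=O)cc(-c3ccc(OCCBr)cc3)oc2c1`: "not active" (no number reported) in a functional assay (Homo sapiens) for antiproliferative activity, read by resazurin assay, with a stated time of 48 h, tested at 10 uM; a higher number here means a stronger effect of the compound at the concentration tested, a lower number a weaker effect
- compound 2, `COc1cc(OC)c2c(=O)cc(-c3ccc(OC4CCN(C)CC4)cc3)oc2c1`: 49%
- compound 3, `COc1cc(OC)c2c(=O)cc(-c3ccc(OCCN4CCCC4=O)cc3)oc2c1`: 14%

All three share the same core and differ only in the group attached to the oxygen on the aromatic ring. Compound 3 stands lowest of the two numbers in this assay; its nearest neighbour is compound 2, and the step of a number 35 percentage points lower from compound 2 to compound 3 (beyond the scatter) lies beyond the scatter. For compound 1 only a limit was reported, without a number.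

Compound 4, `COc1cc(OC)c2c(=O)cc(-c3ccc(OCCN)cc3)oc2c1`, carries the change (amino in place of 2-oxopyrrolidin-1-yl on a saturated chain carbon, two bonds along the chain from an oxygen on an aromatic ring). Within the data shown here, no measured step mirrors this exact change. Among the measured compounds shown here, the one step that bears on the same position, a number 35 percentage points lower from compound 2 to compound 3 (beyond the scatter), shows that swapping the group on this oxygen can move the read-out a great deal, so a sizeable step in either direction is possible, but its direction cannot be read from the data at hand.

Compound 4 is therefore expected near 30%, within 5% to 60%, which means an estimated step of a number 16 percentage points higher from compound 3 to compound 4 (beyond the scatter) that is uncertain in size and direction.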

Compound 4, a percentage reported as inhibition, at one concentration (the size of the read-out at that concentration, not a potency): 35%
Compound 4: middle estimate off by 5 percentage points, on the low side; measured number inside the range.
By their numbers in this assay, from the lowest: compound 3; then compound 4; then compound 2.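

In this assay there is a step of a number 21 percentage points higher from compound 3 to compound 4 (beyond the scatter) when 2-(2-oxopyrrolidin-1-yl)ethoxy becomes 2-aminoethoxy, so on this chain the lactam ring can go without any loss in the read-out, and the smaller group does better. The entering amino group has 1 heavy atom where the leaving group has 6, which shows that bulk on the chain is not required for the effect seen here. Even so, the amino compound does not match the best number of the set: replacing 1-methylpiperidin-4-yl with 2-aminoethyl on the same oxygen gives a number 14 percentage points lower from compound 2 to compound 4 (beyond the scatter) and places this change between the other two groups. Nothing shown here explains these differences.

From the compounds shown here alone, it remains open whether the free amine itself matters or whether substituted amines on the same chain, such as 2-(dimethylamino)ethyl or 2-(pyrrolidin-1-yl)ethyl, would do as well or better. The effect of chain length is also unsettled, and a longer chain such as 3-aminopropyl would test whether the distance between the amine and the oxygen on the aromatic ring changes the read-out.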